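The compounds below may be only part of what the source reports. "The series", "measured", "known", "first", "only" and "open" are said of these compounds alone.

Of the compounds shown here, two have so far been measured in a functional assay on A549 cells (Homo sapiens) for inhibition; on this read-out lower numbers stand for stronger inhibition of growth and higher numbers for weaker inhibition of growth. Compound 1 `Cc1cccc(NS(=O)(=O)c2ccc(C(C)(C)C)cc2)c1` gives 80000 nM, and compound 2 `COc1ccc(S(=O)(=O)Nc2ccc(C)c(O)c2)cc1` gives 51000 nM. The number of compound 2 sits within the scatter of that of compound 1, so the two cannot be told apart. Compound 3 `Cc1ccc(NS(=O)(=O)c2ccc(Br)cc2)cc1O` has not yet been measured; it differs from compound 2 by bromo in place of methoxy on an aromatic carbon. For the measured compounds named here, no measured pair shows this change, so no step beyond the scatter is expected in either direction. Compound 3 is estimated at 51000 nM, expected between 20000 nM and 130000 nM. The expected step is no change at the digits printed from compound 2 to compound 3 (within the scatter).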

Compound 3, concentration for 50% growth inhibition: 20000 nM
Compound 3: the middle estimate sits 2.6-fold (0.41 log units) above what was measured; the range from low to high includes it.
By their numbers in this assay, from the lowest: compound 3; then compounds 2 and 1 (each within the scatter of the next).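

In this assay, bromo in place of methoxy on an aromatic carbon, para to a large group, gives a 2.6-fold lower number from compound 2 to compound 3 (0.41 log units; beyond the scatter). For the compounds shown here, this is the first sign that the number responds to what sits at this position, although the step is modest and rests on a single pair. No measurement shown here explains the step.

From the compounds shown here alone, whether an amine or a carboxylic acid at this position would move the number further remains open. So does whether the same change would give a similar step on the core of compound 1.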